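Urea series: adding a second trifluoromethyl on the aryl urea

The source may report more compounds than this note shows. Statements on the series, on what has been measured and on what is new or still open speak of the compounds shown alone.

Two compounds of the series carry measured numbers. Compound 1 `COc1cccc(-c2nc3sccn3c2-c2ccnc(NCCNC(=O)Nc3cc(C(F)(F)F)cc(C(F)(F)F)c3)n2)c1` bears a methoxy on one aryl ring and two trifluoromethyl groups on the urea aryl; in a functional assay on A375P cells (Homo sapiens) for antiproliferative activity, read by MTT assay, with a stated time of 48 h (a higher number here means a weaker inhibitor, a lower number a stronger inhibitor), compound 1 gives 4300 nM. Compound 2 `O=C(NCCNc1nccc(-c2c(-c3cccc(O)c3)nc3sccn23)n1)Nc1cccc(C(F)(F)F)c1` carries a hydroxy in place of the methoxy and a single trifluoromethyl on the urea aryl; in this assay compound 2 gives 4200 nM. Within the data shown here, the two numbers lie within the usual scatter of each other, so neither can be called the stronger inhibitor; compound 2 is simply the one whose number is taken as the starting point here.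

Compound 3 `O=C(NCCNc1nccc(-c2c(-c3cccc(O)c3)nc3sccn23)n1)Nc1cc(C(F)(F)F)cc(C(F)(F)F)c1` is not yet measured. It differs from compound 2 in one place: trifluoromethyl in place of hydrogen on an aromatic carbon, meta to a trifluoromethyl group, so that the urea aryl of compound 3 matches that of compound 1. Among the measured compounds shown here, no step between measured compounds is available for this change. Because compound 1, which already carries the two trifluoromethyl groups, gives 4300 nM, a step no larger than the scatter is expected, with no clear direction. Compound 3 is therefore estimated at 4000 nM, within 1500 nM to 11000 nM, which means an expected step of a 1.1-fold lower number from compound 2 to compound 3 (0.02 log units; within the scatter).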

Compound 3, half-maximal inhibitory concentration: > 10000 nM
Compound 3: no number, only a limit; the forecaster's own chance of this, stated with the estimate: 5%; middle value at least 2.5-fold (0.39 log units) away from the limit.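

In this assay, the second trifluoromethyl on the urea aryl, meta to a trifluoromethyl group, is not a silent change on the hydroxy compound: the single-place change gives an at least 2.3-fold higher number from compound 2 to compound 3 (0.37 log units; beyond the scatter). With the two trifluoromethyl groups held fixed, hydrogen in place of methyl on an oxygen on an aromatic ring gives an at least 2.3-fold higher number from compound 1 to compound 3 (0.36 log units; beyond the scatter), so this urea aryl is tolerated alongside the methoxy of compound 1 but not alongside the hydroxy of compound 3. Compound 3 stands at a limit of the assay and not at a number, so both steps fix only the least possible size of the change: the limit of > 10000 nM in this assay, at which 1 of the 3 values shown sits.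

The compounds shown leave open whether the second trifluoromethyl is itself a loss on a methoxy compound, a question that needs the methoxy partner with a single trifluoromethyl on the urea aryl, and whether the two changes act independently or only in combination. Also open, from the compounds shown here alone, is how a chlorine, a nitrile or an amine in this place on the urea aryl would read in this assay.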